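Trifluoromethyl removed from the biaryl sulfonamide core

The source may report more compounds than this note shows. Statements on the series, on what has been measured and on what is new or still open speak of the compounds shown alone.

Compound 1 `CC1CCN(C2CCN(S(=O)(=O)c3cccc(-c4ccccc4C(F)(F)F)c3)CC2)CC1` gives > 5000 nM in an ADME assay on HCT-116 cells (Homo sapiens) for cytotoxicity, read by CellTiter-Glo, with a stated time of 72 h (a higher number here means a weaker inhibitor, a lower number a stronger inhibitor), a limit of the assay rather than a number.
Compound 2 `Cc1ccc(-c2ccccc2S(=O)(=O)N2CCC(N3CCC(C)CC3)CC2)cc1` gives > 5000 nM in this assay, again a limit of the assay.
Compound 3 `CC1CCN(C2CCN(S(=O)(=O)c3ccccc3-c3ccc(Cl)cc3)CC2)CC1` gives > 5000 nM in this assay, again a limit of the assay.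

Compound 1 therefore stands at the limit, and all three measured compounds sit there together, as the limit of > 5000 nM in this assay, at which 3 of the 3 values shown sit, records. The step that the two limits leave unreadable from compound 2 to compound 3 between compound 2 and compound 3 cannot be read as a size, since both ends are limits.

The unmeasured compound 4 `CC1CCN(C2CCN(S(=O)(=O)c3cccc(-c4ccccc4)c3)CC2)CC1` differs from compound 1 by hydrogen in place of trifluoromethyl on an aromatic carbon. Within the data shown here, no measured step concerns this change, so there is nothing to calibrate its size or direction in this assay. The only bearing comes from the fact that every measured value sits at the limit, which gives no hint that a small change at the aromatic ring would move compound 4 into a readable range. The expectation is therefore a step that the limit leaves unreadable from compound 1 to compound 4, not beyond the scatter, and most likely a further limit. Compound 4 is estimated at 8000 nM, with a range from 3000 nM to 30000 nM.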

Compound 4, half-maximal inhibitory concentration: > 5000 nM
Compound 4: a limit, no number; the forecaster's own chance of this, stated with the estimate: 85%; the middle value does not contradict the limit.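

Between compound 1 and compound 4, the exchange of trifluoromethyl for hydrogen gives no step that can be read, and both compounds rest on the same limit: the limit of > 5000 nM in this assay, at which 4 of the 4 values shown sit.

The compounds shown leave open whether any of the four differ from one another in this assay, and whether any change to the shared core would yield a readable value.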